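This account rests on a few compounds, and the source may have more. Where it says the series, first, only, none or still open, it means among the compounds named here.

Working notes on the series. Compound 1 (`ClCc1ccc(Cn2cnc3c(Cl)ncnc32)cc1`) is the starting point of this step; in a functional assay on T47D cells (Homo sapiens) for cytotoxicity, read by sulforhodamine B assay, with a stated time of 48 h (a lower number here means a stronger inhibitor of growth, a higher number a weaker inhibitor of growth), compound 1 stands at "not determined" (no result reported), so no number anchors it. Within the data shown here, the only measured member is compound 2 (`ClCc1ccccc1Cn1cnc2c(Cl)nc(Cl)nc21`), a close relative of compound 3 that carries two chloro groups on the shared core; in this assay compound 2 gives 1990 nM, a moderate inhibition of growth.

The change from compound 1 to compound 3 (`ClCc1ccc(Cn2cnc3c(Cl)nc(Cl)nc32)cc1`) is chloro in place of hydrogen on an aromatic carbon. Among the measured compounds shown here, no measured pair in the set shows this change directly, so the size of the step in this assay cannot be read from a comparison; with compound 1 undetermined, nothing can be said beyond that the outcome is open in either direction.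

The expectation for compound 3 leans on compound 2, whose value 1990 nM is the nearest point of reference. Compound 3 is therefore estimated at 2000 nM in this assay, within a range of 500 nM to 8000 nM.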

Compound 3, concentration for 50% growth inhibition: 1380 nM
Beside the measured number, compound 3's estimate is 1.4-fold (0.16 log units) above it; the range from low to high includes it.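

No new step can be read, as in this assay compound 1 stands at "not determined" (no result reported) while compound 3 gives 1380 nM and the pair allows no comparison. The compounds shown leave open what chloro in place of hydrogen on the shared core does to growth inhibition, and no supporting data bear on this result.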